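Anilino for methoxy on the carbonyl of compound 3

A few compounds are considered here, and "the series" means these few. Any claim that something is new, unique, unknown or untested is made for them only; others in the source may bear on it.

Working notes on three analogues that share one core, all tested in an assay on isolated protein for inhibition of Dipeptidyl peptidase 9 (Homo sapiens); a higher number here means a weaker inhibitor, a lower number a stronger inhibitor. Compound 1 `Cc1nc2cc(-c3ccccc3)nn2c(-c2ccc(Cl)cc2Cl)c1CN` returns in this assay only a limit, > 20000 nM. Compound 2 `Cc1nc2nc(N3CCN(C(=O)OC(C)(C)C)CC3)nn2c(-c2ccc(Cl)cc2Cl)c1CN` likewise gives in this assay only a limit, > 30000 nM. Compound 3 `COC(=O)c1nc2nc(C)c(CN)c(-c3ccc(Cl)cc3Cl)n2n1`, which carries a methoxycarbonyl on the core, is reported in this assay only as a limit, > 30000 nM. Among the compounds with values here, compound 3 therefore stands at no distinct place: every value in the set is a limit, one at the limit of > 20000 nM in this assay, at which 1 of the 3 values shown sits, and two at the limit of > 30000 nM in this assay, at which 2 of the 3 values shown sit, so no order among the three compounds can be read and no measured step exists.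

Compound 4 `Cc1nc2nc(C(=O)Nc3ccccc3)nn2c(-c2ccc(Cl)cc2Cl)c1CN` is the next analogue, not yet measured. It differs from compound 3 by anilino in place of methoxy on a carbonyl carbon; cut one bond further out, methoxycarbonyl becomes phenylcarbamoyl. Since every neighbour sits at a limit, the limit of > 30000 nM in this assay, at which 2 of the 3 values shown sit, included, the step from compound 3 to compound 4 is expected to be none beyond the scatter, a number no higher from compound 3 to compound 4 (the limit leaves the size open), with a limit again the likeliest outcome. Compound 4 is estimated at 30000 nM, within 5000 nM to 100000 nM.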

Compound 4, inhibition constant: > 10000 nM
Compound 4 was reported as a limit; the forecaster's own chance of this, stated with the estimate: 75%; the middle value is on the limit's open side.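

Within the data shown here, compound 3 and compound 4 are both reported only as limits in this assay, so no step between them can be read. The compounds shown leave open whether anilino in place of methoxy on the carbonyl carbon changes inhibition at all.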